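Series notes: (isopropylcarbonyl)amino in place of cyano

The source may hold more compounds than are shown below. What is called first, only, known or untested is meant among the compounds shown, and "the series" means these compounds.

Three members of the series have been measured in an assay on isolated protein for inhibition of serine/threonine-protein kinase 10 (Homo sapiens), read by thermal shift assay, tested at 10 uM; a lower number here means that the compound stabilises the target less, a higher number that the compound stabilises the target more against heat. Compound 1 `Cc1ccc(NC(=O)Nc2cc(C(C)(C)C)nn2-c2ccccc2)cc1` gives 4.7 degrees C; compound 2 `CC(C)(C)c1cc(NC(=O)Nc2ccc(Cl)cc2)n(-c2ccc(C#N)cc2)n1` gives 2.2 degrees C; compound 3 `N#Cc1ccc(-n2nc(C3CC3)cc2NC(=O)Nc2ccc(Cl)cc2)cc1` gives -0.7 degrees C. Compound 2 stands second highest of the three, with compound 1 above it by a margin beyond the scatter and compound 3 below it by a margin beyond the scatter. Within the data shown here, the only single-point step measured, a number 2.9 degrees C lower from compound 2 to compound 3 (beyond the scatter), concerns the substituent on the shared core and not the ring that is altered here. Compound 4 `CC(C)C(=O)Nc1ccc(-n2nc(C(C)(C)C)cc2NC(=O)Nc2ccc(Cl)cc2)cc1` differs from compound 2 by (isopropylcarbonyl)amino in place of cyano on an aromatic carbon. Among the measured compounds shown here, no measured step changes this ring alone; compounds 1 and 2 differ at this ring and elsewhere as well, so their two values cannot be assigned to a single change. With nothing bearing directly on the swap, no shift beyond the scatter is expected, and the step of a number 0.30 degrees C higher from compound 2 to compound 4 (within the scatter) is the estimate. Compound 4 is therefore expected to give 2.5 degrees C in this assay, within a range of 0.5 degrees C to 4.5 degrees C.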

Compound 4, shift of the target's melting temperature: 5.1 degrees C
Estimate against measurement, compound 4: 2.6 degrees C below, and the stated range ends below it.
By their numbers in this assay, from the lowest: compound 3; then compound 2; then compounds 1 and 4 (each within the scatter of the next).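

In this assay, the aromatic carbon para to a large group proves sensitive to substitution: with (isopropylcarbonyl)amino in place of cyano, the step is a number 2.9 degrees C higher from compound 2 to compound 4 (beyond the scatter). Among these compounds, this is the first measured change confined to this ring, and it shows that the larger group, which brings a hydrogen-bond donor that cyano lacks, is accompanied by stronger stabilisation of the target rather than a loss. No supporting data on the origin of this rise are available.

As far as these compounds go, it remains open whether the rise depends on the amide hydrogen, the carbonyl or the isopropyl part, and how a plain amine, an acetylamino group or a carboxylic acid would read at this position. Also open, from the compounds shown here alone, is whether the same swap would carry over to compound 3, which has cyclopropyl in place of tert-butyl.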